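This account rests on a few compounds, and the source may have more. Where it says the series, first, only, none or still open, it means among the compounds named here.

Compound 2 `O=C(/C=C/c1ccccc1F)NNC(=O)c1ccc2c(c1)OCCO2` gives 302000 nM in an ADME assay on cells (Macrophage) for cytotoxicity, read by MTT assay, with a stated time of 24 h (a lower number here means that less compound is tolerated, a higher number that more compound is tolerated), the lowest of the two numbers at hand; compound 1 `O=C(/C=C/c1cccc([N+](=O)[O-])c1)NNC(=O)c1ccc2c(c1)OCCO2` gives 323000 nM in this assay, and the step of a 1.1-fold lower number from compound 1 to compound 2 (0.03 log units; within the scatter) lies within the scatter. Compound 3 `Cc1ccccc1/C=C/C(=O)NNC(=O)c1ccc2c(c1)OCCO2` differs from compound 2 by methyl in place of fluoro on an aromatic carbon, ortho to a large group. For the measured compounds named here, the only measured step that bears on this change is the one from compound 1 to compound 2, in which the exchange of one group on the same ring for another left the number essentially where it was. On that basis the exchange of fluoro for methyl is expected to move the number little, if at all, with no direction that can be claimed beyond the scatter. Compound 3 is therefore estimated to give about 310000 nM in this assay, with a range from 150000 nM to 650000 nM, which means an expected step of a 1.0-fold higher number from compound 2 to compound 3 (0.01 log units; within the scatter).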

Compound 3, half-maximal cytotoxic concentration: 268000 nM
Beside the measured number, compound 3's estimate is 1.2-fold (0.06 log units) above it; measured number inside the range.
By their numbers in this assay, from the lowest: compounds 3, 2 and 1 (each within the scatter of the next).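

In this assay, methyl in place of fluoro on an aromatic carbon, ortho to a large group, gives a 1.1-fold lower number from compound 2 to compound 3 (0.05 log units; within the scatter), so the numbers for these two compounds cannot be told apart at this position. The exchange of 2-methylphenyl for 3-nitrophenyl gives a 1.2-fold lower number from compound 1 to compound 3 (0.08 log units; within the scatter), so all three compounds lie within the scatter of one another, whichever of these three ring groups is present. Nothing at hand accounts for this result.

The compounds shown leave open whether an amine or a carboxylic acid at this position, or a longer chain in place of the methyl, would move the number beyond the scatter. They also leave open whether the same exchange of fluoro for methyl would read alike on another place of the ring.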